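The source may report more compounds than this note shows. Statements on the series, on what has been measured and on what is new or still open speak of the compounds shown alone.

Measured compounds:
Compound 1 `COc1cc(-c2cccc3nc(-c4ccccc4)oc23)cc(OC)c1OC` — 3500 nM
Compound 2 `COc1ccc(-c2nc3cccc(-c4cc(OC)c(OC)c(OC)c4)c3o2)cc1` — > 25000 nM (a limit of the assay)
Compound 3 `COc1cc(-c2cccc3nc(-c4cccc(Cl)c4)oc23)cc(OC)c1OC` — 18500 nM

All three share one core, a phenyl ring attached to it, and a trimethoxyphenyl group on the other side; they differ only in what sits on that phenyl ring. They were tested in a functional assay on U-251 cells (Homo sapiens) for antiproliferative activity, read by MTT assay, with a stated time of 48 h; on this read-out higher numbers stand for weaker inhibition and lower numbers for stronger inhibition. Compound 1 gives 3500 nM, the lowest of the two numbers recorded, so it is the stronger inhibitor of the pair. Compound 3 gives 18500 nM. For compound 2 the result is a limit of the assay, > 25000 nM, not a number.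

Two measured steps begin at compound 1: an at least 7.1-fold higher number from compound 1 to compound 2 (0.85 log units; beyond the scatter) and a 5.3-fold higher number from compound 1 to compound 3 (0.72 log units; beyond the scatter). In both, adding a group to the plain phenyl ring weakened inhibition.

Compound 4 `COc1cc(-c2cccc3nc(-c4cccc(N)c4)oc23)cc(OC)c1OC` differs from compound 1 by amino in place of hydrogen on an aromatic carbon. No amino group has been tested among these compounds, so the comparison rests only on the two steps above, both of which raised the number. A higher number is therefore expected for compound 4 as well, most likely a modest rise. Compound 4 is estimated at 8000 nM, with a range from 2500 nM to 30000 nM. The expected step is a 2.3-fold higher number from compound 1 to compound 4 (0.36 log units; beyond the scatter).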

Compound 4, half-maximal inhibitory concentration: 2200 nM
Estimate against measurement, compound 4: 3.6-fold (0.56 log units) above; measured number below the stated range.
By their numbers in this assay, from the lowest: compounds 4 and 1 (each within the scatter of the next); then compound 3. At a limit, above all of these: compound 2.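

Amino is the first group on the phenyl ring that brings no rise beyond the scatter in this assay, as a 1.6-fold lower number from compound 1 to compound 4 (0.20 log units; within the scatter) shows, so adding a group to this ring does not by itself weaken inhibition. The identity of the group at this carbon matters, since 3-aminophenyl and 3-chlorophenyl differ only in that one group and an 8.4-fold lower number from compound 3 to compound 4 (0.92 log units; beyond the scatter) separates them. Compound 2 carries a limit of the assay and not a number, so an at least 11-fold lower number from compound 2 to compound 4 (1.05 log units; beyond the scatter) is only a floor on that gap: the limit of > 25000 nM in this assay, at which 1 of the 4 values shown sits.

The compounds shown leave open whether a hydroxyl, a methylamino or a dimethylamino group, or an acetamide at this same carbon would keep the number as low as compound 4 does, or would move it towards compound 3. On these data alone, they also do not tell why amino and chloro part so far here, and with one amino compound it remains unknown how much of the result belongs to the amino group's place on the ring.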